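This account rests on a few compounds, and the source may have more. Where it says the series, first, only, none or still open, it means among the compounds named here.

In an ADME assay on L02 cells (Homo sapiens) for cytotoxicity, read by MTT assay, with a stated time of 24 h (a lower number here means a stronger inhibitor, a higher number a weaker inhibitor), compound 1 (`CN1C/C(=C\c2cccnc2)C(=O)/C(=C/c2ccccc2F)C1`) gives 15900 nM while compound 2 (`CN1C/C(=C\c2cccnc2)C(=O)/C(=C/c2ccccc2C(F)(F)F)C1`) gives 14100 nM and compound 3 (`CN1C/C(=C\c2ccncc2)C(=O)/C(=C/c2ccccc2C(F)(F)F)C1`) gives 15800 nM so compound 2 stands within the scatter of both others. Compound 4 (`O=C1/C(=C/c2cccnc2)CNC/C1=C\c1ccccc1C(F)(F)F`) departs from compound 2 in one place (hydrogen in place of methyl on an amine nitrogen in a ring), with hydrogen in place of methyl on an amine nitrogen in a ring. Going by the values given here, the two measured steps (a 1.1-fold lower number from compound 1 to compound 2 (0.05 log units; within the scatter) and a 1.1-fold higher number from compound 2 to compound 3 (0.05 log units; within the scatter)) were both within the scatter, but they change other groups, and no measured pair touches this methyl. Compound 2 at 14100 nM therefore remains the only anchor, no direction can be read from the data, and no step beyond the scatter is expected in this assay (a 1.0-fold lower number from compound 2 to compound 4 (0.00 log units; within the scatter)). Compound 4 is estimated at 14000 nM (expected range 6000 nM to 30000 nM).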

Compound 4, half-maximal inhibitory concentration: 11300 nM
Estimate against measurement, compound 4: 1.2-fold (0.09 log units) above; the measured number falls inside the stated range.
By their numbers in this assay, from the lowest: compounds 4, 2, 3 and 1 (each within the scatter of the next).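

With hydrogen in place of methyl on the amine nitrogen in a ring, this assay shows a 1.2-fold lower number from compound 2 to compound 4 (0.10 log units; within the scatter) and thus no real change. Going by these compounds alone, the earlier compounds varied only the aromatic groups, so this is the first sign that the ring nitrogen, too, can be altered without moving the number beyond the scatter. As far as these compounds go, whether an ethyl, benzyl or acetyl group on this nitrogen would do the same stays open, as does the same change with the pyridin-4-yl group of compound 3. No measurement shown offers an explanation for this result.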